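Side-chain removal tested on the shared core

This account rests on a few compounds, and the source may have more. Where it says the series, first, only, none or still open, it means among the compounds named here.

Of the compounds shown here, three have been measured in an assay on isolated protein for inhibition of tyrosine-protein phosphatase non-receptor type 13 (Homo sapiens), read by spectrophotometry; on this read-out higher numbers stand for weaker inhibition and lower numbers for stronger inhibition. Compound 1 `CCCNC(=O)COc1ccc2cc(C(O)(C(F)(F)F)C(F)(F)F)c(O)cc2c1` carries a propylamino group on the carbonyl carbon of the ether side chain; compound 2 `COc1ccc(CNC(=O)COc2ccc3cc(C(O)(C(F)(F)F)C(F)(F)F)c(O)cc3c2)cc1OC` has 3,4-dimethoxyphenyl in place of ethyl on a saturated chain carbon bound to an amide-type nitrogen; compound 3 `CCN(CC)C(=O)COc1ccc2cc(C(O)(C(F)(F)F)C(F)(F)F)c(O)cc2c1` has diethylamino in place of propylamino on that carbonyl carbon. In this assay compound 1 gives > 20000 nM, which is a limit. Compound 2 gives > 20000 nM, also a limit. Compound 3 gives > 20000 nM, again a limit. The steps a step that the two limits leave unreadable from compound 1 to compound 2, a step that the two limits leave unreadable from compound 1 to compound 3 and a step that the two limits leave unreadable from compound 2 to compound 3 therefore show only that none of the three amides reaches measurable inhibition; compound 3 stands at the same limit as the other two, with no order among them readable, as all three values sit at the limit of > 20000 nM in this assay, at which 3 of the 3 values shown sit.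

Compound 4 `Oc1cc2ccccc2cc1C(O)(C(F)(F)F)C(F)(F)F` removes the side chain entirely: hydrogen in place of (diethylcarbamoyl)methoxy on an aromatic carbon. Going by the values given here, no measured step bears directly on this change, and every measured step is itself unreadable, so no direction can be drawn from the numbers. The bare core is expected to remain at or near the same limit, the step that the limit leaves unreadable from compound 3 to compound 4 being an expectation rather than a reading. For compound 4 in this assay the estimate is 30000 nM, within 5000 nM to 150000 nM.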

Compound 4, half-maximal inhibitory concentration: 128000 nM
Compound 4: middle estimate off by 4.3-fold (0.63 log units), on the low side; measured number inside the range.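

In this assay no new step can be read between compound 4 and either compound 1 or compound 3, since the values of compound 1 and compound 3 are limits, not numbers: the limit of > 20000 nM in this assay, at which 3 of the 4 values shown sit.

The compounds shown leave open whether any side chain on the shared core gives stronger or weaker inhibition than the bare core of compound 4.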